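The source may report more compounds than this note shows. Statements on the series, on what has been measured and on what is new or still open speak of the compounds shown alone.

Measured compounds:
Compound 1 `COc1ccc([C@H]2CC(=O)N(Cc3cccc(N)c3)C2)cc1OC1CCCC1`; in a functional assay on HEK293 cells (Homo sapiens) for cytotoxicity (a lower number here means that less compound is tolerated, a higher number that more compound is tolerated), compound 1 gives > 10000 nM, a limit of the assay rather than a number.
Compound 2 `COc1ccc([C@H]2CC(=O)N(c3ccc(C)c(N)c3)C2)cc1OC1CCCC1`; compound 2 gives > 10000 nM, again a limit.
Compound 3 `COc1ccc([C@H]2CC(=O)N(c3cccc(NCC4CCOC4)c3)C2)cc1OC1CCCC1`; compound 3 gives > 10000 nM, also a limit.

Compound 3 thus stands exactly where the other two stand, at the limit of > 10000 nM in this assay, at which 3 of the 3 values shown sit, and no ordering among the three can be read. Within the data shown here, the one step between compounds that differ in a single place, a step that the two limits leave unreadable from compound 1 to compound 2, is unreadable for the same reason and tells nothing about how large any change could be.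

Compound 4 `COc1ccc([C@H]2CC(=O)N(c3cccc(NS(=O)(=O)c4ccccc4F)c3)C2)cc1OC1CCCC1` differs from compound 3 by (2-fluorophenyl)sulfonyl in place of (oxolan-3-yl)methyl on a nitrogen on an aromatic ring. Among the measured compounds shown here, no measured step touches this nitrogen or this kind of group, so nothing bears on the change directly; the only guidance is that every measured compound, compound 3 among them, sits at the limit. The expected step, a step that the limit leaves unreadable from compound 3 to compound 4, is therefore one of no change beyond the scatter in this assay, with the tolerated concentration once more likely to be reported as a limit. Compound 4 is expected to give 15000 nM, within a range from 5000 nM to 50000 nM.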

Compound 4, half-maximal cytotoxic concentration: > 10000 nM
Compound 4: only a limit was reported; the forecaster's own chance of this, stated with the estimate: 75%; the middle value lies beyond the limit too.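

No new step can be read, as the results for compound 3 and compound 4 in this assay are both limits rather than numbers, and compound 4 stays where the others stand: the limit of > 10000 nM in this assay, at which 4 of the 4 values shown sit.

The compounds shown leave open what concentration of any of the four is actually tolerated in this assay and whether changing the group on the shared core alters it at all.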